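Rearranging the alkyl branch on the shared core

A few compounds are considered here, and "the series" means these few. Any claim that something is new, unique, unknown or untested is made for them only; others in the source may bear on it.

Two members of the series have numbers in a functional assay on cells for antagonist activity at prostaglandin E2 receptor EP1 subtype (Rattus norvegicus), read by fluorescence and calcium flux, with a stated time of 60 s (on this read-out higher numbers stand for weaker inhibition and lower numbers for stronger inhibition), so far. Compound 1 `O=C(O)c1cccc(Cc2c(-c3cccs3)nn3cc(Cl)ccc23)n1` gives 1100 nM in this assay. Among the measured compounds shown here, compound 2 `CC(C)(C)c1nn2cc(Cl)ccc2c1Cc1cccc(C(=O)O)n1` gives 48 nM in this assay; the single change, tert-butyl in place of thiophen-2-yl on an aromatic carbon, brought a 23-fold lower number from compound 1 to compound 2 (1.36 log units; beyond the scatter). On the numbers shown, compound 2 stands lowest of the two, with compound 1 as its only neighbour.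

Compound 3 `CC(C)Cc1nn2cc(Cl)ccc2c1Cc1cccc(C(=O)O)n1` keeps every atom of compound 2 and rejoins them: isobutyl in place of tert-butyl on an aromatic carbon. For the measured compounds named here, no measured step swaps one saturated chain for another at this place; the only step in hand, from compound 1 to compound 2, replaces an aromatic ring by an alkyl branch and is large, so it sets the weight of this position without fixing the direction of a branch change. A modest rise in this assay is expected for compound 3, a 2.5-fold higher number from compound 2 to compound 3 (0.40 log units; beyond the scatter). Compound 3 is estimated at 120 nM, within 40 nM to 400 nM.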

Compound 3, half-maximal inhibitory concentration: 200 nM
Compound 3: middle estimate off by 1.7-fold (0.22 log units), on the low side; the measured number falls inside the stated range.
By their numbers in this assay, from the lowest: compound 2; then compound 3; then compound 1.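

In this assay this position separates two saturated branches built from the same atoms, with a 4.2-fold higher number from compound 2 to compound 3 (0.62 log units; beyond the scatter) for isobutyl in place of tert-butyl; the earlier step set only an aromatic ring against an alkyl branch. Isobutyl still keeps part of the gain over thiophen-2-yl, with a 5.5-fold lower number from compound 1 to compound 3 (0.74 log units; beyond the scatter) for that swap, so among the three compounds the numbers rise from tert-butyl through isobutyl to thiophen-2-yl. No measurement at hand accounts for the gap between the two branches.

Open, as far as these compounds go, is where isopropyl, cyclopropyl or a longer straight chain such as n-pentyl would fall in this order. Also open, from the compounds shown here alone, is whether the order holds once the chlorine or the carboxylic acid on the shared core is replaced, for instance by a nitrile or an amide.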